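From Isopropyl to Hexyl on the Ring Nitrogen

The compounds below may be only part of what the source reports. "The series", "measured", "known", "first", "only" and "open" are said of these compounds alone.

Three measured compounds share one core and differ only in the group on an amine nitrogen in a ring. In an assay on membranes from brain for displacement of a labelled ligand from Sigma non-opioid intracellular receptor 1 (Cavia porcellus), read by scintillation counting, with a stated time of 120 min (on this read-out lower numbers stand for stronger inhibition and higher numbers for weaker inhibition), compound 1 `CCN1CCN(CCC(=O)Nc2nc3c(C)cccc3s2)CC1` gives 543 nM. Compound 3 `CCCCN1CCN(CCC(=O)Nc2nc3c(C)cccc3s2)CC1` gives 204 nM in this assay. Compound 2 `Cc1cccc2sc(NC(=O)CCN3CCN(C(C)C)CC3)nc12` gives 1300 nM in this assay, the highest of the three numbers. Compound 4 `CCCCCCN1CCN(CCC(=O)Nc2nc3c(C)cccc3s2)CC1` carries hexyl in place of isopropyl on an amine nitrogen in a ring. The step that bears most directly on it is a 6.4-fold lower number from compound 2 to compound 3 (0.80 log units; beyond the scatter), and the step of a 2.7-fold lower number from compound 1 to compound 3 (0.43 log units; beyond the scatter) points the same way, both beyond the scatter. Compound 4 is therefore expected to give a lower number, estimated at 120 nM with a range from 40 nM to 400 nM. The expected step is an 11-fold lower number from compound 2 to compound 4 (1.03 log units; beyond the scatter).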

Compound 4, inhibition constant: 238 nM
Compound 4: the middle estimate sits 2.0-fold (0.30 log units) below what was measured, and the stated range covers the measured number.
By their numbers in this assay, from the lowest: compounds 3 and 4 (each within the scatter of the next); then compound 1; then compound 2.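

Lengthening the chain on the ring nitrogen from butyl to hexyl gives no readable gain in this assay (a 1.2-fold higher number from compound 3 to compound 4 (0.07 log units; within the scatter)), so the fall in the number seen up to butyl does not carry on to hexyl. Hexyl still keeps the advantage over the shorter groups (a 5.5-fold lower number from compound 2 to compound 4 (0.74 log units; beyond the scatter); a 2.3-fold lower number from compound 1 to compound 4 (0.36 log units; beyond the scatter)). No measurement shown explains this levelling. On these data alone, whether a longer chain such as octyl would hold this level remains open. So does the effect of a benzyl group on the same nitrogen.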